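A few compounds are considered here, and "the series" means these few. Any claim that something is new, unique, unknown or untested is made for them only; others in the source may bear on it.

Measured compounds:
compound 1, `Fc1ccc(C2(c3ccc(F)cc3)CNC(c3cccc(C(F)(F)F)c3)=N2)cc1`: 6.2 nM
compound 2, `O=[N+]([O-])c1cccc(C2=NC(c3ccc(F)cc3)(c3ccc(F)cc3)CN2)c1`: 4.3 nM
compound 3, `CC(=O)c1cccc(C2=NC(c3ccc(F)cc3)(c3ccc(F)cc3)CN2)c1`: 44 nM

All three share one core and differ only in the group on the aromatic ring attached to the carbon with a double bond to nitrogen. In an assay on LM cells for displacement of a labelled ligand from Neuropeptide Y receptor type 5 (Homo sapiens) (on this read-out higher numbers stand for weaker inhibition and lower numbers for stronger inhibition), compound 3 stands highest of the three numbers: the steps of a 7.1-fold higher number from compound 1 to compound 3 (0.85 log units; beyond the scatter) and a 10-fold higher number from compound 2 to compound 3 (1.01 log units; beyond the scatter) both lie beyond the scatter, whereas a 1.4-fold lower number from compound 1 to compound 2 (0.16 log units; within the scatter) stays within it. Compound 4, `Fc1ccc(C2(c3ccc(F)cc3)CNC(c3ccncc3)=N2)cc1`, has not been measured; it differs from compound 3 by pyridin-4-yl in place of 3-acetylphenyl on a carbon with a double bond to nitrogen. Within the data shown here, no measured step exchanges the whole aromatic ring; each only swaps a group on that ring, so none gives a direct guide here. The step of a 1.1-fold lower number from compound 3 to compound 4 (0.04 log units; within the scatter) is therefore expected to be modest, with direction uncertain. For compound 4 the estimate in this assay is 40 nM, between 8 nM and 200 nM.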

Compound 4, half-maximal inhibitory concentration: 160 nM
Compound 4: the middle estimate sits 4.0-fold (0.60 log units) below what was measured, and the stated range covers the measured number.
By their numbers in this assay, from the lowest: compounds 2 and 1 (each within the scatter of the next); then compound 3; then compound 4.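

In this assay, among these compounds, the one exchange of the whole aromatic ring at this position raises the number: a 3.6-fold higher number from compound 3 to compound 4 (0.56 log units; beyond the scatter), and a 37-fold higher number from compound 2 to compound 4 (1.57 log units; beyond the scatter). Pyridin-4-yl therefore does not keep the level of 3-nitrophenyl or 3-acetylphenyl, and compound 4 stands highest of the four. No measurement shown bears on the reason for this rise. The compounds shown do not separate the effect of the ring nitrogen from that of losing the group on the ring, and plain phenyl would address this. As far as these compounds go, how an amine or a carboxylic acid on the ring would read also stays open.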